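The compounds below may be only part of what the source reports. "The series", "measured", "known", "first", "only" and "open" are said of these compounds alone.

Compound 1 `CC(C)C[C@H](N)CN(C(=O)[C@@H]1C[C@H]1c1ccccc1)c1ccc(-c2ccccc2)cc1`: 880 nM
Compound 2 `CO[C@H](C)[C@H](N)CN(C(=O)[C@@H]1C[C@H]1c1ccccc1)c1ccc(-c2ccccc2)cc1`: 0.68 nM

In a functional assay for agonist activity at G protein-coupled receptor 88 (Homo sapiens), read by HTRF and cAMP accumulation (on this read-out higher numbers stand for an effect only at larger amounts of compound and lower numbers for an effect already at smaller amounts), compound 1 gives 880 nM, the higher of the two measured numbers. Compound 2 gives 0.68 nM, and the step from one to the other is a 1300-fold lower number from compound 1 to compound 2 (3.11 log units; beyond the scatter). Compound 3 `CC(C)C[C@H](N)CN(C(=O)[C@@H]1C[C@H]1c1ccccc1)c1ccc(-c2cccnc2)cc1` differs from compound 1 by pyridin-3-yl in place of phenyl on an aromatic carbon. Within the data shown here, the single measured step changes the chain carbon bound to the amine nitrogen, not the aromatic ring, so no measured step bears on this change. For compound 3 a step of a 1.0-fold higher number from compound 1 to compound 3 (0.01 log units; within the scatter) is expected, within the scatter. Compound 3 is therefore estimated at 900 nM, with a range from 150 nM to 5000 nM.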

Compound 3, half-maximal effective concentration: 10000 nM
Compound 3: middle estimate off by 11-fold (1.05 log units), on the low side, and the stated range ends below it.
By their numbers in this assay, from the lowest: compound 2; then compound 1; then compound 3.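

The aromatic position para to a large group is sensitive: in this assay, pyridin-3-yl in place of phenyl gives an 11-fold higher number from compound 1 to compound 3 (1.06 log units; beyond the scatter), even though the heavy-atom count stays the same. The earlier pair changed only the chain, so it could not show that this distant ring also matters. Nothing measured here explains the rise.

Still open, going by these compounds, is whether pyridin-4-yl, with its nitrogen elsewhere in the ring, would give a similar number. Also open, on these data alone, is whether the same swap would cost as much on compound 2, with its 1-methoxyethyl group.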